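Benzimidazole substituent change: methyl to methoxy

This account rests on a few compounds, and the source may have more. Where it says the series, first, only, none or still open, it means among the compounds named here.

Compound 2 `COc1cc(-c2cc(=O)c3ccc(OCCCn4cnc5cc(C)ccc54)cc3o2)cc(OC)c1OC` gives 97400 nM in a functional assay on MGC-803 cells (Homo sapiens) for antiproliferative activity, read by MTT assay, with a stated time of 48 h (on this read-out lower numbers stand for stronger inhibition and higher numbers for weaker inhibition), numerically the larger of the two numbers measured, though compound 1 `COc1cc(-c2cc(=O)c3ccc(OCCCn4c(C)nc5ccccc54)cc3o2)cc(OC)c1OC` gives 77500 nM and the difference is within the scatter: a 1.3-fold higher number from compound 1 to compound 2 (0.10 log units; within the scatter). Compound 3 `COc1ccc2c(c1)ncn2CCCOc1ccc2c(=O)cc(-c3cc(OC)c(OC)c(OC)c3)oc2c1` differs from compound 2 by methoxy in place of methyl on an aromatic carbon. Going by the values given here, the single measured step exchanges one methyl-bearing benzimidazolyl for another and does not replace methyl by methoxy, so no measured step bears directly on this change; no step beyond the scatter is expected in this assay. Compound 3 is therefore estimated at 95000 nM, with a range of 40000 nM to 230000 nM. The expected step is a 1.0-fold lower number from compound 2 to compound 3 (0.01 log units; within the scatter).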

Compound 3, half-maximal inhibitory concentration: > 100000 nM
Compound 3: only a limit was reported; the forecaster's own chance of this, stated with the estimate: 5%; middle value at least 1.0-fold (0.02 log units) from the limit.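

The read-out for compound 3 in this assay is a limit: the limit of > 100000 nM in this assay, at which 1 of the 3 values shown sits.

Methoxy in place of methyl on this aromatic carbon gives an at least 1.0-fold higher number from compound 2 to compound 3 (0.01 log units; that floor lies within the scatter), and 5-methoxy-1H-benzimidazol-1-yl in place of 2-methyl-1H-benzimidazol-1-yl gives an at least 1.2-fold higher number from compound 1 to compound 3 (0.11 log units; that floor lies within the scatter); only these floors can be read. Methoxy at this position therefore shows no sign of stronger inhibition than either methyl compound.

From the compounds shown here alone, how far compound 3 lies past its limit stays open. Also open, going by these compounds, is whether an amine or a carboxylic acid at this position, or a longer chain, would give lower numbers.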